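From 4-bromophenyl to 4-chlorophenyl: one halogen exchange

The source may report more compounds than this note shows. Statements on the series, on what has been measured and on what is new or still open speak of the compounds shown alone.

In an ADME assay on cells (Hepatocyte, Homo sapiens) for metabolic stability (on this read-out higher numbers stand for a longer-lived compound and lower numbers for a shorter-lived compound), compound 1 (`CCc1nc2ccc(Cl)cn2c1C(=O)NCCOc1ccc(Br)cc1`) gives 0.587 h and sits within the scatter of compound 2 (`COc1ccc2nc(C)c(C(=O)NCCOc3ccc(Br)cc3)n2c1`), which gives 0.903 h on the same read-out. Compound 3 (`CCc1nc2ccc(Br)cn2c1C(=O)NCCOc1ccc(Br)cc1`) gives 0.263 h in this test. Compound 4 (`CCc1nc2ccc(Cl)cn2c1C(=O)NCCOc1ccc(Cl)cc1`) keeps the core of compound 1 and alters only the halogen of the 4-bromophenoxy group (chloro in place of bromo on an aromatic carbon), with chloro in place of bromo on an aromatic carbon.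

For the measured compounds named here, the only measured single-place step is a 2.2-fold lower number from compound 1 to compound 3 (0.35 log units; beyond the scatter) with bromo in place of chloro on an aromatic carbon of the core. Going by the values given here, it runs the opposite way and sits at a different place, and no measured pair tests the 4-bromophenyl group itself. It therefore serves only as a loose outer guide to size, and a small rise, probably within the scatter, is expected. The expected change is a 1.2-fold higher number from compound 1 to compound 4 (0.08 log units; within the scatter) in this estimate. For compound 4 the estimated half-life is 0.7 h with an expected range from 0.33 h to 1.4 h in repeat measurements.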

Compound 4, half-life: 0.215 h
The estimate for compound 4 lay 3.3-fold (0.51 log units) above the measured number; the measured number lies below the stated range.
By their numbers in this assay, from the lowest: compounds 4 and 3 (each within the scatter of the next); then compounds 1 and 2 (each within the scatter of the next).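

For the compounds shown here, the exchange of 4-bromophenyl for 4-chlorophenyl gives, in this assay, a 2.7-fold lower number from compound 1 to compound 4 (0.44 log units; beyond the scatter), so the halogen at this place, which no earlier pair had tested, moves the half-life beyond the scatter. Read with a 2.2-fold lower number from compound 1 to compound 3 (0.35 log units; beyond the scatter), a step that puts bromo in place of chloro on the core, it shows that exchanges in opposite directions at two different places both lower the number from compound 1, so neither halogen is favoured at both places. Nothing shown here bears on why the number falls at either place.

As far as these compounds go, whether the same exchange has a like effect on the core of compound 2 remains open. So does how the half-life would respond to a fluoro, methoxy or nitrile group at this place on the phenyl ring.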